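Swapping tert-butyl for pentan-3-yl on a stable amide

The source may hold more compounds than are shown below. What is called first, only, known or untested is meant among the compounds shown, and "the series" means these compounds.

Compound 1, `CCC(CC)C(=O)N/C(=N/c1nccn1C(C)C)Nc1ccc(Cl)c(Cl)c1`, gives in an in vitro ADME assay on microsomes from liver (Homo sapiens) for metabolic stability, read by LC-MS, tested at 1 uM; a higher number here means that the compound lasts longer, a lower number that the compound disappears faster > 1 h, a limit of the assay and not a number.
Compound 2, `CC(C)n1ccnc1/N=C(/NC(=O)C(C)(C)C)Nc1ccc(Cl)c(Cl)c1`, gives in this assay > 1 h, again a limit.
Compound 3, `CC(C)(C)C(=O)N/C(=N/c1nccn1C(C)(C)C)Nc1ccc(Cl)c(Cl)c1`, gives in this assay > 1 h, once more a limit.

Compound 3 therefore stands at the upper limit of this assay, and since all three values shown are limits, the limit of > 1 h in this assay, at which 3 of the 3 values shown sit, is the whole of the evidence. Compound 4, `CCC(CC)C(=O)N/C(=N/c1nccn1C(C)(C)C)Nc1ccc(Cl)c(Cl)c1`, differs from compound 3 in one place: pentan-3-yl in place of tert-butyl on a carbonyl carbon. Among the compounds with values here, two measured steps touch this change. The first, a step that the two limits leave unreadable from compound 1 to compound 2, is the same exchange run in the opposite direction; the second, a step that the two limits leave unreadable from compound 2 to compound 3, leads into compound 3. Both run between limits and so show no size. Compound 1, which carries the pentan-3-yl group that enters here, also sits at the limit. With every value at the limit, no step beyond the scatter can be read in either direction, and the expectation in this assay is that compound 4 again reaches the limit. The expected step that the limit leaves unreadable from compound 3 to compound 4 is accordingly none beyond the scatter. Compound 4 is estimated at 2 h, between 1 h and 6 h, most likely reported once more as a limit.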

Compound 4, half-life: 0.433 h
For compound 4 the middle estimate is 4.6-fold (0.66 log units) above the measured one; measured number below the stated range.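

In this assay, the exchange on the carbonyl carbon now has a readable direction, with pentan-3-yl in place of tert-butyl giving an at least 2.3-fold lower number from compound 3 to compound 4 (0.36 log units; beyond the scatter). The other change that leads to compound 4, methyl in place of hydrogen on the saturated chain carbon bound to an aromatic nitrogen, gives an at least 2.3-fold lower number from compound 1 to compound 4 (0.36 log units; beyond the scatter). Neither change could be read by itself among the earlier compounds, whose steps are all unreadable; within the compounds shown, the fall appears only where pentan-3-yl and the added methyl occur together, and compound 4 is the one compound that gives a number and not a limit: the limit of > 1 h in this assay, at which 3 of the 4 values shown sit.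

From the compounds shown here alone, how far compound 1 and compound 3 actually lie beyond their limits remains unknown, so the full size of both steps stays open, and so does the part of compound 4 that is lost in the microsomes. Going by these compounds, it is also open whether a smaller or a ring-shaped group on the carbonyl carbon, such as an ethyl or a cyclopentyl group, would behave like tert-butyl or like pentan-3-yl when paired with the same added methyl.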